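Dihydrobenzofuran sulfonamide replaces nitrophenyl on a shared core

The source may report more compounds than this note shows. Statements on the series, on what has been measured and on what is new or still open speak of the compounds shown alone.

Measured compounds in an assay on MDA-MB-231 cells for binding affinity to C-X-C chemokine receptor type 4 (Homo sapiens), read by fluorescence and microscopy, with stated times of 10 min and 30 min; a lower number here means that less compound is needed, a higher number that more compound is needed for the effect:
compound 1 `O=C(NCc1ccc(CNS(=O)(=O)c2cccc(C(F)(F)F)c2)cc1)c1ccc(F)cc1`: 100 nM
compound 2 `O=C(NCc1ccc(CNS(=O)(=O)c2ccc([N+](=O)[O-])cc2)cc1)c1ccc(F)cc1`: 1000 nM
compound 3 `O=C(NCc1ccc(CNS(=O)(=O)c2cccc(F)c2)cc1)c1ccc(F)cc1`: 1000 nM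

Compound 2 sits level with compound 3 at the digits given, and the two together give the highest numbers of the three; compound 1 lies furthest away, with a 10-fold higher number from compound 1 to compound 2 (1.00 log units; beyond the scatter). The unmeasured compound 4 `O=C(NCc1ccc(CNS(=O)(=O)c2ccc3c(c2)CCO3)cc1)c1ccc(F)cc1` differs from compound 2 at the sulfonyl sulfur: a group of 9 heavy atoms (8 carbon, 1 oxygen; one five-membered non-aromatic ring with 1 hetero atom, one six-membered aromatic ring of carbon only) in place of a group of 9 heavy atoms (6 carbon, 1 nitrogen, 2 oxygen; one six-membered aromatic ring of carbon only), on a sulfonyl sulfur. Going by the values given here, no measured pair shows this exact exchange. Among the compounds with values here, the steps that bear on it are the changes of the group on the sulfonyl sulfur, a 10-fold higher number from compound 1 to compound 2 (1.00 log units; beyond the scatter) and no change at the digits printed from compound 2 to compound 3 (within the scatter), which show that such exchanges can move the number by a modest step or leave it within the scatter. For compound 4 a modest improvement is therefore expected, a 2.0-fold lower number from compound 2 to compound 4 (0.30 log units; within the scatter), with a wide range. The estimate for compound 4 in this assay is 500 nM, between 100 nM and 3000 nM.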

Compound 4, effective concentration (reported as EC, without a stated level of effect): 10 nM
Compound 4: middle estimate off by 50-fold (1.70 log units), on the high side; the measured number lies below the stated range.
By their numbers in this assay, from the lowest: compound 4; then compound 1; then compounds 2 and 3 (each within the scatter of the next).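

In this assay, going by these compounds alone, the group on the sulfonyl sulfur can move the number further than the earlier compounds showed, with a 100-fold lower number from compound 2 to compound 4 (2.00 log units; beyond the scatter) and a 100-fold lower number from compound 3 to compound 4 (2.00 log units; beyond the scatter) as large steps. The new group, with its five-membered non-aromatic ring holding one hetero atom, also improves on the lowest earlier number, with a 10-fold lower number from compound 1 to compound 4 (1.00 log units; beyond the scatter), so compound 4 gives the lowest number of the four. Nothing given here accounts for these steps.

The compounds shown leave open whether the oxygen in that ring is needed. They also leave open how a methoxy group or an amine on the aromatic ring would compare.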